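The compounds below may be only part of what the source reports. "The series", "measured", "known", "first", "only" and "open" are said of these compounds alone.

Going by the values given here, compound 2 `Cc1c(CCCC(=O)O)c2cccc(/C=C/c3ccc(OCCCCc4ccccc4)cc3)c2n1CC(=O)O` is one of two compounds so far assessed in a physicochemical assay for permeability, using PAMPA, with a stated time of 4 h, at pH 7.4, tested at 50 uM; a higher number here means that the compound crosses the layer faster, a lower number that the compound crosses the layer more slowly. Compound 2 sits at a limit of the assay, giving < 0.05 10^-6 cm/s. Compound 1 `O=C(O)CCCc1cn(CC(=O)O)c2c(/C=C/c3ccc(OCCCCc4c(F)ccc(F)c4F)cc3)cccc12` likewise returns only a limit, < 0.05 10^-6 cm/s. Among the compounds with values here, both readings therefore rest at the same edge of the measurement (the limit of < 0.05 10^-6 cm/s in this assay, at which 2 of the 2 values shown sit), so no order between compound 1 and compound 2 can be drawn, and no measured step between any pair of compounds is available. Compound 3 `Cc1c(CCCC(=O)O)c2cccc(/C=C/c3ccc(OCCCCc4c(F)c(F)cc(F)c4F)cc3)c2n1CC(=O)O` has not yet been tested in this assay; it differs from compound 2 by 2,3,5,6-tetrafluorophenyl in place of phenyl on a saturated chain carbon, four bonds along the chain from an oxygen on an aromatic ring. With both measured compounds at the limit, nothing suggests a rise beyond the usual scatter, and compound 3 is expected to remain at the limit as well. The estimated step that the limit leaves unreadable from compound 2 to compound 3 is accordingly small. Compound 3 is estimated at 0.03 10^-6 cm/s, with a range from 0.01 10^-6 cm/s to 0.1 10^-6 cm/s.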

Compound 3, apparent permeability: 0.5 10^-6 cm/s
Beside the measured number, compound 3's estimate is 17-fold (1.22 log units) below it, and the stated range ends below it.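

In this assay, replacing phenyl with 2,3,5,6-tetrafluorophenyl on a saturated chain carbon, four bonds along the chain from an oxygen on an aromatic ring, gives an at least 10-fold higher number from compound 2 to compound 3 (1.00 log units; beyond the scatter). The earlier compounds offered no readable value, but this shows that the reading can respond to a change at this position, and compound 3 is the only compound shown with a value that is a number rather than a limit. The step has only a lower bound, as the reading for compound 2 is a limit: the limit of < 0.05 10^-6 cm/s in this assay, at which 2 of the 3 values shown sit.

The compounds shown leave open whether a single fluorine, a chlorine or a trifluoromethyl group on the same phenyl would also lift the reading off the limit. They also leave open how large the full step is and whether the same change would have a similar effect on another core.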